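Chain Lengthened by One Carbon: Compound 3 to Compound 4

The source may hold more compounds than are shown below. What is called first, only, known or untested is meant among the compounds shown, and "the series" means these compounds.

Compound 3 `CCCCCCCCCCc1cc2cn(COCCO)c(O)nc-2n1` is tested in a functional assay on HEL cells (Homo sapiens), read by microscopy (a higher number here means that more compound is tolerated, a lower number that less compound is tolerated), where compound 3 gives 80000 nM. Among the numbers shown it stands lowest; the nearest is compound 1 `CCCCCCCc1cc2cn(COCCO)c(=O)nc2o1`, which gives 400000 nM. Compound 2 `O=c1nc2occc2cn1COCCO` reaches only the limit > 400000 nM, so no number is known for it. For the measured compounds named here, the one measured step, a number no lower from compound 1 to compound 2 (the limit leaves the size open), removes a whole heptyl chain, and its size is not readable (the limit of > 400000 nM in this assay, at which 1 of the 3 values shown sits). Compound 4 `CCCCCCCCCCCc1cc2cn(COCCO)c(O)nc-2n1` differs from compound 3 by methyl in place of hydrogen on a saturated chain carbon, ten or more bonds along the chain from an aromatic carbon. Going by the values given here, no measured step adds a single carbon to such a chain, so no step beyond the scatter is expected, and the change no change at the digits printed from compound 3 to compound 4 (within the scatter) is estimated to stay within it. Compound 4 is therefore expected at 80000 nM, between 40000 nM and 160000 nM.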

Compound 4, minimum cytotoxic concentration: 80000 nM
The estimate for compound 4 equals the measured number at the digits printed; low and high end bracket the measured number.
By their numbers in this assay, from the lowest: compounds 3 and 4 (each within the scatter of the next); then compound 1.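

In this assay, adding methyl in place of hydrogen on a saturated chain carbon, ten or more bonds along the chain from an aromatic carbon, gives no change at the digits printed from compound 3 to compound 4 (within the scatter). For the compounds shown here, this is the first readable step at this far end of the chain, and it shows that one added carbon here leaves the number in place. No measurement shown here accounts for this result. The compounds shown leave open whether a longer chain, or an amine at the end of the chain, would keep the number at this level.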